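Aryl exchange from compound 2 to compound 4

The source may hold more compounds than are shown below. What is called first, only, known or untested is meant among the compounds shown, and "the series" means these compounds.

Measured in a functional assay on UACC-62 cells (Homo sapiens) for cytotoxicity, read by sulforhodamine B assay; a lower number here means a stronger inhibitor of growth, a higher number a weaker inhibitor of growth:
- compound 1 `CC1=CC[C@@H]([C@@](C)(O)CCCC(C)(C)NC=S)CC1`: 9960 nM
- compound 2 `CC1=CC[C@@H]([C@@](C)(O)CCCC(C)(C)NC(=S)N/N=C\c2ccc(C)cc2)CC1`: 11600 nM
- compound 3 `COc1ccc(/C=N\NC(=S)NC(C)(C)CCC[C@](C)(O)[C@@H]2CC=C(C)CC2)cc1`: 7420 nM

Compound 2 stands within the scatter of both compound 1 and compound 3, so the three values do not separate. Compound 4 `CC1=CC[C@@H]([C@@](C)(O)CCCC(C)(C)NC(=S)N/N=C\c2cccc([N+](=O)[O-])c2)CC1` differs from compound 2 as follows: 3-nitrophenyl in place of 4-methylphenyl on a carbon with a double bond to nitrogen. Among the measured compounds shown here, the one measured step bearing on this change is a 1.6-fold lower number from compound 2 to compound 3 (0.19 log units; within the scatter), which puts methoxy in place of methyl on an aromatic carbon and stays within the scatter. For the measured compounds named here, no measured compound carries the 3-nitrophenyl group, so this guide is weak and the range stays wide. No shift beyond the scatter is expected in this assay, and the expected step is a 1.3-fold lower number from compound 2 to compound 4 (0.11 log units; within the scatter). For compound 4 the estimate is 9000 nM, with an expected range of 3500 nM to 20000 nM.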

Compound 4, concentration for 50% growth inhibition: 7840 nM
Estimate against measurement, compound 4: 1.1-fold (0.06 log units) above; the measured number falls inside the stated range.
By their numbers in this assay, from the lowest: compounds 3, 4, 1 and 2 (each within the scatter of the next).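

In this assay, 3-nitrophenyl in place of 4-methylphenyl on the carbon with a double bond to nitrogen gives a 1.5-fold lower number from compound 2 to compound 4 (0.17 log units; within the scatter) and 3-nitrophenyl in place of 4-methoxyphenyl gives a 1.1-fold higher number from compound 3 to compound 4 (0.02 log units; within the scatter) and both steps stay within the scatter. The position therefore accepts a nitro-bearing aryl group as well as the methyl- and methoxy-bearing ones, with no separation among compounds 2, 3 and 4. The compounds shown leave open whether an amine or a carboxylic acid on the aryl ring, or a longer alkyl chain in its place, would shift the number beyond the scatter. Nothing available accounts for this flat result.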